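A hydroxypiperidine in place of cyclopentylpiperazine

The compounds below may be only part of what the source reports. "The series", "measured", "known", "first", "only" and "open" are said of these compounds alone.

Compound 1 `Cc1nc(N2CCN(C3CCCC3)CC2)nc2ccc(NC(=O)COc3ccc(Cl)cc3)cc12` sits in the middle of a small set of three in a functional assay on CHO-K1 cells for antagonist activity at melanin-concentrating hormone receptor 1 (Homo sapiens), read by inositol phosphate accumulation (a higher number here means a weaker inhibitor, a lower number a stronger inhibitor), where compound 1 gives 150 nM. Compound 2 `Cc1nc(N2CCC(NC(=O)C(C)C)CC2)nc2ccc(NC(=O)COc3ccc(Cl)cc3)cc12` gives 54 nM in this assay, the lowest number of the three, and compound 3 `Cc1nc(N2CCC(N3CCCC3)CC2)nc2ccc(NC(=O)C(C)Oc3ccc(Cl)cc3)cc12` gives 401 nM, the highest; both gaps from compound 1 lie beyond the scatter of repeated measurements. No two of these compounds differ in only one place, so the numbers show only that substituents of rather different character on the shared core can land anywhere across this span.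

Compound 4 `CCC1(O)CCN(c2nc(C)c3cc(NC(=O)COc4ccc(Cl)cc4)ccc3n2)CC1` has not yet been measured. It differs from compound 1 by 4-ethyl-4-hydroxypiperidin-1-yl in place of 4-cyclopentylpiperazin-1-yl on an aromatic carbon. With no single-point comparison to lean on, the step from compound 1 to compound 4 in this assay is expected to be modest, of uncertain direction, and possibly within the scatter, so that a 1.2-fold higher number from compound 1 to compound 4 (0.08 log units; within the scatter) is the estimate. Compound 4 is thus expected to give about 180 nM in this assay, with a likely range from 50 nM to 700 nM.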

Compound 4, half-maximal inhibitory concentration: 384 nM
The estimate for compound 4 lay 2.1-fold (0.33 log units) below the measured number, within the range that was stated.
By their numbers in this assay, from the lowest: compound 2; then compound 1; then compounds 4 and 3 (each within the scatter of the next).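

Among the compounds shown here, the replacement of 4-cyclopentylpiperazin-1-yl by 4-ethyl-4-hydroxypiperidin-1-yl on the aromatic carbon between two ring nitrogen atoms gives the first single-place comparison in this set, with a 2.6-fold higher number from compound 1 to compound 4 (0.41 log units; beyond the scatter) in this assay. The position is therefore not indifferent to this change, which makes compound 4 a weaker inhibitor than compound 1 even though the entering group brings one hydrogen-bond donor where the leaving group has none. No measurement shown here accounts for the step.

Going by these compounds, whether the step follows from the hydroxyl group, the ethyl group or the loss of the cyclopentyl ring stays open. So does what 4-hydroxypiperidin-1-yl without the ethyl group, or 4-aminopiperidin-1-yl, would give at this position on the shared core.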